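Ethoxy ester replacing the aryl ketone: notes on compound 3

This account rests on a few compounds, and the source may have more. Where it says the series, first, only, none or still open, it means among the compounds named here.

Measured in a functional assay on PC-3 cells (Homo sapiens) for inhibition, read by MTT assay, with a stated time of 48 h; on this read-out higher numbers stand for weaker inhibition and lower numbers for stronger inhibition
Compound 1 `COc1ccc(-n2c(SCC(=O)c3ccccc3)nnc2-c2cc(OC)c(OC)c(OC)c2)cc1`: > 60000 nM (a limit)
Compound 2 `COc1ccc(-n2c(SCC(=O)c3ccc(F)cc3)nnc2-c2cc(OC)c(OC)c(OC)c2)cc1`: 58300 nM

Among the measured compounds shown here, compound 2 holds the only actual number so far, 58300 nM. Compound 1 gives only a limit, > 60000 nM.

The next compound to be read is compound 3 `CCOC(=O)CSc1nnc(-c2cc(OC)c(OC)c(OC)c2)n1-c1ccc(OC)cc1`, which carries ethoxy in place of 4-fluorophenyl on a carbonyl carbon.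

For the measured compounds named here, one measured step bears on this change, and only indirectly. It is fluoro in place of hydrogen on an aromatic carbon, an at least 1.0-fold lower number from compound 1 to compound 2 (0.01 log units; that floor lies within the scatter). That step rests on (the limit of > 60000 nM in this assay, at which 1 of the 2 values shown sits), so its true size is not known. Going by the values given here, no measured step covers the loss of the whole ring, which leaves the value of compound 2, 58300 nM, as the only anchor.

No shift beyond the scatter is expected in either direction, and the estimated step is a 1.2-fold lower number from compound 2 to compound 3 (0.07 log units; within the scatter). A reading reported only as a limit is also quite possible. For compound 3 the expected value is 50000 nM, with an estimated range of 15000 nM to 90000 nM.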

Compound 3, half-maximal inhibitory concentration: > 60000 nM
Compound 3 gave a limit, no number (the forecaster's own chance of this, stated with the estimate: 45%); at least 1.2-fold (0.07 log units) between middle value and limit.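

Exchanging 4-fluorophenyl for ethoxy on a carbonyl carbon gives an at least 1.0-fold higher number from compound 2 to compound 3 (0.01 log units; that floor lies within the scatter) in this assay, and this figure is only a floor, since compound 3 reads as a limit. From the compounds shown here alone, the ester therefore brings no readable gain in inhibition over the aryl ketone of compound 2, and the size of any loss stays unknown; the step between the two limit compounds, compound 1 and compound 3, cannot be read. This change removes the whole aromatic ring from the position, yet the series still yields only one actual number, so the position gives little to work with at this level of inhibition: the limit of > 60000 nM in this assay, at which 2 of the 3 values shown sit.

Going by these compounds, whether a carboxylic acid, an amide or a longer chain on this carbonyl carbon would bring the reading to a real number remains open, as does the true distance of compound 3 from compound 2. Also open, on these data alone, is whether a chloro or methoxy group in place of the fluoro on the aromatic ring would move the value of compound 2 beyond the usual scatter.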